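The compounds below may be only part of what the source reports. "The series", "measured", "known", "first", "only" and "open" are said of these compounds alone.

Measured in a functional assay on MDA-MB-468 cells (Homo sapiens) for antiproliferative activity; a lower number here means a stronger inhibitor, a higher number a weaker inhibitor:
- compound 1 `CC(=O)Nc1ccc(-c2nc3ccccc3s2)cc1C`: > 10000 nM
- compound 2 `CC(=O)Nc1ccc(-c2nc3ccccc3s2)cc1Br`: > 100 nM
- compound 3 `CC(=O)Nc1ccc(-c2nc3ccccc3s2)cc1I`: > 100 nM

All three readings are limits, not numbers.

Compound 3 gives > 100 nM, which is a limit. It therefore sits at the limit of > 100 nM in this assay, at which 2 of the 3 values shown sit, and the series has no exact potency to start from.

The next compound is compound 4 `O=C(CCl)Nc1ccc(-c2nc3ccccc3s2)cc1I`. Its difference from compound 3 is chloro in place of hydrogen on a saturated chain carbon bound to a carbonyl carbon. Cut one bond further out, this reads methyl to chloromethyl, so the acetamido group becomes ((chloromethyl)carbonyl)amino.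

The measured steps offer little guidance. They are a step that the two limits leave unreadable from compound 1 to compound 2, a step that the two limits leave unreadable from compound 1 to compound 3 and a step that the two limits leave unreadable from compound 2 to compound 3. All three are exchanges on an aromatic carbon, none has a readable size, and none involves a saturated chain carbon. No size or direction can be carried over from them, so only a loose expectation is possible in this assay.

The estimate rests on compound 3 alone, whose > 100 nM is a limit. The expected change is a step that the limit leaves unreadable from compound 3 to compound 4, and this estimated step is poorly bounded. For compound 4 the expected value is 2000 nM, with an estimated range from 150 nM to 20000 nM.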

Compound 4, half-maximal inhibitory concentration: > 10 nM
Compound 4: no number, only a limit (the forecaster's own chance of this, stated with the estimate: 45%); the middle value lies beyond the limit too.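

Compound 4 gives > 10 nM in this assay, which is a limit and not a number. Compound 3 also gives only a limit, so no step can be read between compound 3 and compound 4. The compounds shown leave open whether chloro in place of hydrogen on this saturated chain carbon changes potency at all, and in which direction.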